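Chloromethylphenyl amide expected to restore dopamine receptor efficacy

A few compounds are considered here, and "the series" means these few. Any claim that something is new, unique, unknown or untested is made for them only; others in the source may bear on it.

Measured compounds:
compound 1 `O=C(NCN1CCC(c2cccc[n+]2[O-])CC1)c1cc(Cl)cc(Cl)c1`, 64%
compound 2 `COc1cc(C(=O)NCN2CCC(c3cccc[n+]3[O-])CC2)ccc1Cl`, 54%
compound 3 `O=C(NCN1CCC(c2cccc[n+]2[O-])CC1)c1ccccn1`, 40%

In a functional assay on HEK293 cells for agonist activity at D(4) dopamine receptor (Homo sapiens), read by FLIPR (on this read-out higher numbers stand for larger maximal responses and lower numbers for smaller maximal responses), compound 3 gives the lowest number of the three measured compounds. Compound 2 lies above it, and compound 1 higher still, both differences beyond the scatter. Within the data shown here, the step of a number 24 percentage points lower from compound 1 to compound 3 (beyond the scatter) is the only single-point change among the measured compounds, and it shows that pyridin-2-yl in place of 3,5-dichlorophenyl on the carbonyl carbon costs a modest amount of efficacy.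

Compound 4 `Cc1cc(C(=O)NCN2CCC(c3cccc[n+]3[O-])CC2)ccc1Cl` has not yet been measured. It differs from compound 3 as follows: 4-chloro-3-methylphenyl in place of pyridin-2-yl on a carbonyl carbon

This change runs in the opposite sense to the step from compound 1 to compound 3: a carbon-only aromatic ring bearing a chlorine returns to the carbonyl carbon. The two chlorine-bearing phenyl amides, compound 1 and compound 2, both sit well above compound 3, so a rise beyond the scatter is expected for compound 4, of roughly the size seen in a number 24 percentage points lower from compound 1 to compound 3 (beyond the scatter) but reversed. The step is estimated as a number 17 percentage points higher from compound 3 to compound 4 (beyond the scatter). Compound 4 is therefore expected to reach 57%, within a range from 45% to 70%.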

Compound 4, largest response reached (reported as efficacy), in percent of the reference or control that the assay uses: 62%
Beside the measured number, compound 4's estimate is 5 percentage points below it; the measured number falls inside the stated range.
By their numbers in this assay, from the lowest: compound 3; then compounds 2, 4 and 1 (each within the scatter of the next).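

At the carbonyl carbon, 4-chloro-3-methylphenyl in place of pyridin-2-yl gives a number 22 percentage points higher from compound 3 to compound 4 (beyond the scatter) in this assay, so the fall seen in a number 24 percentage points lower from compound 1 to compound 3 (beyond the scatter) is not tied to the 3,5-dichlorophenyl group alone and a second carbon-only aromatic ring also stands clear of pyridin-2-yl at this position. The two phenyl groups themselves are not separated, with a number 2 percentage points lower from compound 1 to compound 4 (within the scatter), which shows that this position accepts a methyl and a single chlorine on the ring as well as two chlorines, with no measurable change in maximal response. Methyl in place of methoxy on an aromatic carbon gives a number 8 percentage points higher from compound 2 to compound 4 (within the scatter), so this exchange on the ring also cannot be read as a real change. Nothing available here explains why pyridin-2-yl and the carbon-only rings differ. The compounds shown leave open whether a plain phenyl ring carrying no chlorine, a saturated cyclohexyl group on the carbonyl carbon, or an amine or a carboxylic acid on the aromatic ring would keep the response at the level of the chlorine-bearing rings.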